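The source may hold more compounds than are shown below. What is called first, only, known or untested is meant among the compounds shown, and "the series" means these compounds.

Compound 1: `Nc1scc(CN2CCN(c3cc(Cl)cc(Cl)c3)CC2)c1C(=O)c1ccc(Cl)cc1` gives 1%
Compound 2: `Nc1scc(CN2CCN(c3cccc(F)c3)CC2)c1C(=O)c1cccc(C(F)(F)F)c1` gives 0%

Both compounds share the same core, an amino-thiophene carrying a ketone and a piperazine arm, and both were tested in an assay on CHO cells for displacement of a labelled ligand from adenosine receptor A3 (Homo sapiens), read by scintillation counting, with a stated time of 120 min, tested at 10 uM; a lower number here means less inhibition, a higher number more inhibition at the concentration tested (going by the name of the read-out). There compound 1 gives 1%, and compound 2 gives 0%. Compound 2 sits within the usual scatter of compound 1, so the two numbers cannot be told apart; neither shows any real displacement of the labelled ligand at the concentration tested.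

Compound 3, `Nc1scc(CN2CCN(c3cccc(F)c3)CC2)c1C(=O)c1ccc(Cl)cc1`, has not yet been measured. It differs from compound 2 in one place: 4-chlorophenyl in place of 3-(trifluoromethyl)phenyl on a carbonyl carbon. The 4-chlorophenyl that enters is the same ketone substituent found in compound 1, whose value in this assay was also essentially nil.

For the measured compounds named here, with no measured step on record, the expectation in this assay is for no change beyond the scatter. Compound 3 is therefore expected to give about 2%, somewhere between -6% and 12%. This estimate implies a step of a number 2 percentage points higher from compound 2 to compound 3 (within the scatter), which is expected to remain within the scatter.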

Compound 3, a percentage reported as inhibition, at one concentration (the size of the read-out at that concentration, not a potency): 4%
Estimate against measurement, compound 3: 2 percentage points below, within the range that was stated.
By their numbers in this assay, from the lowest: compounds 2, 1 and 3 (each within the scatter of the next).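

In this assay, putting 4-chlorophenyl in place of 3-(trifluoromethyl)phenyl on a carbonyl carbon gives a number 4 percentage points higher from compound 2 to compound 3 (within the scatter) for this step, so these two aromatic rings cannot be told apart at this position. For the compounds shown here, the first comparison at the other position, 3-fluorophenyl in place of 3,5-dichlorophenyl on an amine nitrogen in a ring, gives a number 3 percentage points higher from compound 1 to compound 3 (within the scatter) and likewise shows no readable difference, so neither place has yet revealed a change that matters in this test. Nothing available here accounts for the uniformly low numbers.

All three compounds carry a substituted phenyl ring at both positions. Going by these compounds, whether a non-aromatic group such as cyclohexyl on the carbonyl carbon, or a carboxylic acid or an amine on either phenyl ring, would produce real displacement remains open.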